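Methyl in Place of Hydrogen on the Anilino Ring of Compound 3

A few compounds are considered here, and "the series" means these few. Any claim that something is new, unique, unknown or untested is made for them only; others in the source may bear on it.

Measured so far in an assay on CHO cells for displacement of a labelled ligand from adenosine receptor A1 (Homo sapiens), read by scintillation counting, with a stated time of 120 min, tested at 1 uM; a higher number here means more inhibition at the concentration tested (going by the name of the read-out), a lower number less inhibition:
compound 1 `Cc1nc2sc(-c3ccco3)nc2c(=O)[nH]1` gives 37%
compound 2 `Cc1nc2sc(-n3ccnc3)nc2c(=O)[nH]1` gives 1%
compound 3 `Cc1nc2sc(Nc3ccccc3)nc2c(=O)[nH]1` gives 24%

The three compounds share one core and differ only in the group carried on one aromatic carbon. Within the data shown here, the single step between compounds that differ in one place is a number 36 percentage points lower from compound 1 to compound 2 (beyond the scatter), a change of one ring for another. Compound 3 stands second highest of the three numbers in this assay: compound 1 is above it by an amount beyond the scatter, and compound 2 is below it by an amount beyond the scatter.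

Compound 4 `Cc1ccc(Nc2nc3c(=O)[nH]c(C)nc3s2)cc1` differs from compound 3 by methyl in place of hydrogen on an aromatic carbon, the methyl entering on an aromatic carbon of a six-membered aromatic ring of carbon only, para to a large group. Among the measured compounds shown here, no measured step concerns this kind of change: the step from compound 1 to compound 2 replaced a whole ring, whereas here a single carbon is added to a ring that stays. With nothing to point either way, the step of a number 1 percentage points higher from compound 3 to compound 4 (within the scatter) is expected to stay within the scatter. Compound 4 is therefore estimated at 25% in this assay, expected to fall between 8% and 45%.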

Compound 4, a percentage reported as inhibition, at one concentration (the size of the read-out at that concentration, not a potency): 20%
Compound 4: middle estimate off by 5 percentage points, on the high side, and the stated range covers the measured number.
By their numbers in this assay, from the lowest: compound 2; then compounds 4 and 3 (each within the scatter of the next); then compound 1.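

In this assay, among these compounds, the swap of hydrogen for methyl gives a number 4 percentage points lower from compound 3 to compound 4 (within the scatter) and so does not separate the two compounds, the first reading on a ring that stays in place, on an aromatic carbon para to a large group. Where the replacement of one whole ring by another moved the number beyond the scatter, adding this single carbon to the anilino ring leaves no difference the assay can resolve, though this rests on one pair of compounds. No evidence bearing on this result is available.

Still open, on these data alone, is whether a different group on this carbon, such as an amine, a carboxylic acid or a longer chain, would give a step beyond the scatter. Also open, as far as these compounds go, is whether methyl on the other carbons of this ring would read the same.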